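The source may report more compounds than this note shows. Statements on the series, on what has been measured and on what is new or still open speak of the compounds shown alone.

Compounds measured in an ADME assay on HEK293 cells (Homo sapiens) for cytotoxicity, read by MTT assay, with a stated time of 48 h; a higher number here means a weaker inhibitor, a lower number a stronger inhibitor:
compound 1 `COc1cc(NC(=O)c2cc(C(F)(F)F)cc(C(F)(F)F)c2)ccc1NS(=O)(=O)C(F)(F)F`, > 250000 nM
compound 2 `CS(=O)(=O)Nc1ccc(NC(=O)c2cc(C(F)(F)F)cc(C(F)(F)F)c2)cc1Cl`, 185000 nM.

For compound 1 the value in this assay is a limit of the assay, not a number. Compound 2 therefore supplies the only number shown in this assay, the other value being a limit, as the limit of > 250000 nM in this assay, at which 1 of the 2 values shown sits, records. Among the measured compounds shown here, no step between measured compounds is available. Compound 3 `O=C(Nc1ccc(NS(=O)(=O)C(F)(F)F)c(Cl)c1)c1cc(C(F)(F)F)cc(C(F)(F)F)c1` differs from compound 2 by trifluoromethyl in place of methyl on a sulfonyl sulfur. Compound 3 is expected to sit close to compound 2, with any step a 1.1-fold higher number from compound 2 to compound 3 (0.06 log units; within the scatter) likely not beyond the scatter; the estimate for compound 3 is 210000 nM, between 90000 nM and 450000 nM.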

Compound 3, half-maximal inhibitory concentration: > 250000 nM
Compound 3 ended at the assay's limit; the forecaster's own chance of this, stated with the estimate: 45%; middle value at least 1.1-fold (0.07 log units) from the limit.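

In this assay compound 3 gives a limit of the assay, not a number, so trifluoromethyl in place of methyl on a sulfonyl sulfur can be read only as a floor: an at least 1.3-fold higher number from compound 2 to compound 3 (0.13 log units; that floor lies within the scatter). Among the compounds shown here, the change therefore shows no step beyond the scatter at this position, and the one number remains that of compound 2. The step for chloro in place of methoxy on an aromatic carbon cannot be read, and the limit now holds most of the series: the limit of > 250000 nM in this assay, at which 2 of the 3 values shown sit.

Actual values for compound 1 and compound 3 remain open. So does the effect in this assay of an ethyl group or a longer chain on the sulfonyl sulfur.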